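A few compounds are considered here, and "the series" means these few. Any claim that something is new, unique, unknown or untested is made for them only; others in the source may bear on it.

Working notes on the series. In a functional assay on MGC-803 cells (Homo sapiens) for inhibition, read by MTT assay, with a stated time of 48 h (on this read-out higher numbers stand for weaker inhibition and lower numbers for stronger inhibition), compound 2 `Cc1ccc(NC(=O)NC(=O)c2ccc(OCc3cccc(C(F)(F)F)c3)cc2)cc1-c1nc2ccccc2[nH]1` gives 13100 nM, which is the lower of the two numbers recorded so far. Compound 1 `Cc1ccc(NC(=O)NC(=O)c2ccc(OCc3cccc(Cl)c3)cc2)cc1-c1nc2ccccc2[nH]1` gives 20800 nM in this assay, and the step of a 1.6-fold lower number from compound 1 to compound 2 (0.20 log units; within the scatter) does not separate the two compounds on this read-out. Compound 3 `Cc1ccc(NC(=O)NC(=O)c2ccc(OCc3ccccc3F)cc2)cc1-c1nc2ccccc2[nH]1` has not yet been measured in this assay; it differs from compound 2 in one place: 2-fluorophenyl in place of 3-(trifluoromethyl)phenyl on a saturated chain carbon bound to an oxygen on an aromatic ring. Among the compounds with values here, the only measured step that bears on this change is the one from compound 1 to compound 2, which also exchanged one substituent on the ring bound to the saturated chain carbon and stayed within the scatter. Nothing in the recorded numbers points to a substituent change on this ring producing a step beyond the scatter, so for compound 3 the expected step of a 1.2-fold higher number from compound 2 to compound 3 (0.09 log units; within the scatter) is no step beyond the scatter in either direction. Within the data shown here, the estimate for compound 3 in this assay is 16000 nM, with a range from 6000 nM to 45000 nM, the width reflecting that only one comparable step is available.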

Compound 3, half-maximal inhibitory concentration: 2520 nM
The estimate for compound 3 lay 6.3-fold (0.80 log units) above the measured number, and the stated range ends above it.
By their numbers in this assay, from the lowest: compound 3; then compounds 2 and 1 (each within the scatter of the next).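

In this assay, the group on the saturated chain carbon bound to an oxygen on an aromatic ring proves able to shift the number beyond the scatter: 2-fluorophenyl in place of 3-(trifluoromethyl)phenyl gives a 5.2-fold lower number from compound 2 to compound 3 (0.72 log units; beyond the scatter), and 2-fluorophenyl in place of 3-chlorophenyl gives an 8.3-fold lower number from compound 1 to compound 3 (0.92 log units; beyond the scatter). The exchange between 3-chlorophenyl and 3-(trifluoromethyl)phenyl had left this position looking insensitive, but that holds only for those two groups, and 2-fluorophenyl stands apart from both. No supporting data bear on why this change lowers the number.

As far as these compounds go, each step to compound 3 changes both the substituent and its place on the ring, so it remains open whether a 3-fluorophenyl or a 2-chlorophenyl at this carbon would stand with compound 3 or with compounds 1 and 2. Also open, from the compounds shown here alone, is how an unsubstituted phenyl, or a phenyl carrying an amine or a carboxylic acid, would read here, and whether the number for 2-fluorophenyl is the lower end of this series or only one point along it.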